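Sulfonamide variation on a shared benzoxazole-free core, step to methyl

The source may report more compounds than this note shows. Statements on the series, on what has been measured and on what is new or still open speak of the compounds shown alone.

Measured compounds:
Compound 1, `O=S(=O)(Nc1ccc2oc(-c3ccccc3)nc2c1)c1ccccc1F`. In an assay on cells for inhibition of HSP60/HSP10 (Homo sapiens), with a stated time of 60 min (on this read-out higher numbers stand for weaker inhibition and lower numbers for stronger inhibition), compound 1 gives > 100000 nM, which is a limit of the assay.
Compound 2, `O=S(=O)(Nc1ccc2oc(-c3ccccc3)nc2c1)c1ccc(O)cc1`. In this assay compound 2 gives 88000 nM.

For the measured compounds named here, compound 2 holds the only actual number in this assay; the one other value recorded is a limit, so compound 2 cannot be ranked against it. The next compound, compound 3, is `CS(=O)(=O)Nc1ccc2oc(-c3ccccc3)nc2c1`. It differs from compound 2 by methyl in place of 4-hydroxyphenyl on a sulfonyl sulfur.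

Going by the values given here, the only measured step at the same sulfonyl sulfur is an at least 1.1-fold lower number from compound 1 to compound 2 (0.05 log units; that floor lies within the scatter), which rests on the limit of > 100000 nM in this assay, at which 1 of the 2 values shown sits, and lies within scatter. That step swapped one aryl group for another; nothing measured removes the aryl group altogether, so it gives no direction for the present change. With compound 2 already close to the ceiling of this assay, the expectation is a number near or past that ceiling rather than a gain.

Compound 3 is expected at 150000 nM, range 50000 nM to 400000 nM. The step this estimate implies is a 1.7-fold higher number from compound 2 to compound 3 (0.23 log units; within the scatter).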

Compound 3, half-maximal inhibitory concentration: > 100000 nM
Compound 3 gave a limit, no number; the forecaster's own chance of this, stated with the estimate: 60%; the middle value is on the limit's open side.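

In this assay compound 3 gives > 100000 nM, which is a limit of the assay and not a number. Methyl in place of 4-hydroxyphenyl on a sulfonyl sulfur gives an at least 1.1-fold higher number from compound 2 to compound 3 (0.05 log units; that floor lies within the scatter), so this first removal of the aryl group at this position brings no lower number, while the true size of the step stays unknown. The step linking the other two limit-bound compounds cannot be read, and the series now offers only one actual number, with the remaining values sitting at a single ceiling: the limit of > 100000 nM in this assay, at which 2 of the 3 values shown sit.

On these data alone, whether an unsubstituted phenyl, a benzyl or a dimethylamino group on a sulfonyl sulfur would give a number well clear of this limit remains open. For the compounds shown here, with compound 2 the only compound holding an actual number, it is also open whether a carboxylic acid or an amine in place of the hydroxyl of its 4-hydroxyphenyl would shift the read-out beyond the usual scatter.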